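A few compounds are considered here, and "the series" means these few. Any claim that something is new, unique, unknown or untested is made for them only; others in the source may bear on it.

Measured so far in a functional assay on the whole organism (blood) with Rattus norvegicus as the target, with stated times of 24 h and 1 h, at a dose of 5 mg/kg by the intraperitoneal route; on this read-out higher numbers stand for a stronger effect at the one dose given and lower numbers for a weaker effect:
compound 1 `COc1ncccc1C(=O)NCCC1CCN(S(=O)(=O)NC(=O)NC[C@@H]2C[C@@H]3CC[C@@H]2O3)CC1` gives 34%
compound 2 `COc1ncccc1C(=O)NCCC1CCN(S(=O)(=O)NC(=O)NC[C@@H]2C[C@@H]3CC[C@@H]2C3)CC1` gives 35%
compound 3 `COc1ncccc1C(=O)NCCC1CCN(S(=O)(=O)NC(=O)NCC2CCCO2)CC1` gives 16%

Compound 3 stands lowest of the three. Between compound 1 and compound 2 the change was a number 1 percentage points higher from compound 1 to compound 2 (within the scatter), so those two cannot be told apart. The drops to compound 3 were a number 18 percentage points lower from compound 1 to compound 3 (beyond the scatter) and a number 19 percentage points lower from compound 2 to compound 3 (beyond the scatter), both clear, and both mark the loss of a larger two-ring group in favour of a single five-membered ring with one hetero atom.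

Compound 4 `COc1ncccc1C(=O)NCCC1CCN(S(=O)(=O)NC(=O)NCC2CCCCO2)CC1` differs from compound 3 in one place: oxan-2-yl in place of oxolan-2-yl on a saturated chain carbon bound to an amide-type nitrogen. The change enlarges the single ring by one atom but does not restore a two-ring group. Among the compounds with values here, the only bearing steps, to compound 3 from compound 1 and compound 2, show that a smaller group on this carbon weakened the effect; a step back toward a larger group might recover a little. Within the data shown here, no measured pair tests a single ring grown by one atom. The expected step is small, a number 6 percentage points higher from compound 3 to compound 4 (within the scatter), most likely within the scatter. For compound 4 the estimate is 22%, with a range of 8% to 38%.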

Compound 4, a percentage reported as activity, at one dose (the size of the read-out at that dose, not a potency): 12%
For compound 4 the middle estimate is 10 percentage points above the measured one, within the range that was stated.
By their numbers in this assay, from the lowest: compounds 4 and 3 (each within the scatter of the next); then compounds 1 and 2 (each within the scatter of the next).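

In this assay, enlarging the single ring from oxolan-2-yl to oxan-2-yl on this saturated chain carbon gives a number 4 percentage points lower from compound 3 to compound 4 (within the scatter), so adding this one ring atom has no readable effect. The six-membered ring still falls clearly short of both two-ring groups, with a number 22 percentage points lower from compound 1 to compound 4 (beyond the scatter) and a number 23 percentage points lower from compound 2 to compound 4 (beyond the scatter), so among these compounds a larger single ring does not recover the effect seen with the two-ring groups. No measurement shown here explains why the two-ring groups give the higher numbers.

Still open, from the compounds shown here alone, is whether a single carbon-only ring such as cyclohexyl would behave like the oxan-2-yl group. Going by these compounds, it is also open whether a ring amine such as piperidin-2-yl, or a single ring carrying a methyl group, would come closer to the two-ring groups.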